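Swapping a Morpholine for a Benzimidazole at the Amine

A few compounds are considered here, and "the series" means these few. Any claim that something is new, unique, unknown or untested is made for them only; others in the source may bear on it.

Compound 1 `COc1ccc(CNC(=O)c2cccc(C(C)Oc3ccnc(Nc4cnn(C)c4)c3)c2)cc1OC`: 38500 nM
Compound 2 `Cc1ccc(CNC(=O)c2cccc(C(C)Oc3ccnc(NN4CCOCC4)c3)c2)cc1`: > 100000 nM

Both were tested in a functional assay on NCI-H3122 cells (Homo sapiens) for antiproliferative activity, read by MTT assay, with a stated time of 48 h; a lower number here means a stronger inhibitor, a higher number a weaker inhibitor. Compound 1 gives 38500 nM. For compound 2 the reported value is only a limit of the assay, > 100000 nM, and it sits at the limit of > 100000 nM in this assay, at which 1 of the 2 values shown sits. Compound 3 `Cc1ccc(CNC(=O)c2cccc(C(C)Oc3ccnc(Nc4nc5ccccc5[nH]4)c3)c2)cc1` differs from compound 2 by 1H-benzimidazol-2-yl in place of morpholin-4-yl on a nitrogen on an aromatic ring. Among the compounds with values here, no measured pair shares this change, so its size is unknown; the expected step is toward a stronger inhibitor, beyond the usual scatter, an at least 5.0-fold lower number from compound 2 to compound 3 (0.69 log units; beyond the scatter). Compound 3 is expected at 20000 nM, within a range from 3000 nM to 100000 nM.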

Compound 3, half-maximal inhibitory concentration: 9400 nM
Compound 3: middle estimate off by 2.1-fold (0.33 log units), on the high side, and the stated range covers the measured number.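

Within the data shown here, on a nitrogen on an aromatic ring, the group carried there clearly matters in this assay: 1H-benzimidazol-2-yl in place of morpholin-4-yl brings an at least 10-fold lower number from compound 2 to compound 3 (1.02 log units; beyond the scatter) and gives the first measured step at this place. The true size of the step cannot be stated because compound 2 is reported only as a limit: the limit of > 100000 nM in this assay, at which 1 of the 3 values shown sits.

Going by these compounds, whether both rings of 1H-benzimidazol-2-yl are needed stays open. A plain imidazole or a phenyl group on that nitrogen would help to answer this.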